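A few compounds are considered here, and "the series" means these few. Any claim that something is new, unique, unknown or untested is made for them only; others in the source may bear on it.

Compound 1, `N[C@H]1CC[C@H](Nc2c(C(=O)NCc3ccc(Cl)cc3)nc(Br)c3cccnc23)CC1`, gives 1000 nM in a functional assay on MDA-MB-435 cells (Homo sapiens) for cytotoxicity, read by MTT assay, with a stated time of 72 h; a lower number here means a stronger inhibitor, a higher number a weaker inhibitor. Compound 2, `N[C@H]1CC[C@H](Nc2c(C(=O)NCc3ccc(F)cc3)nc(Br)c3cccnc23)CC1`, gives 6000 nM in this assay. Compound 3, `N[C@H]1CC[C@H](Nc2c(C(=O)NC3CCCCC3)nc(Br)c3cccnc23)CC1`, gives only a limit of the assay, > 10000 nM, in this assay.

Compound 3 thus stands at the weak end of the three, with no exact number, only the limit recorded as the limit of > 10000 nM in this assay, at which 1 of the 3 values shown sits. Its cyclohexyl group on the amide-type nitrogen sets it apart from the two compounds carrying an aromatic group there: the step of an at least 10-fold higher number from compound 1 to compound 3 (1.00 log units; beyond the scatter) and the step of an at least 1.6-fold higher number from compound 2 to compound 3 (0.22 log units; that floor lies within the scatter) both point the same way, toward weaker inhibition when cyclohexyl enters.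

Compound 4, `C[C@H](NC(=O)c1nc(Br)c2cccnc2c1N[C@H]1CC[C@H](N)CC1)c1ccc(F)cc1`, reverses that kind of change: 1-(4-fluorophenyl)ethyl in place of cyclohexyl on an amide-type nitrogen. The new group is the 4-fluorobenzyl group of compound 2 with one more carbon on the linking carbon, so the closest measured guide is the step from compound 2 to compound 3 read backwards, which only sets a floor within the scatter. Compound 4 is therefore expected to land near compound 2, that is at about 5000 nM in this assay, within 1500 nM to 15000 nM, an estimated step of an at least 2.0-fold lower number from compound 3 to compound 4 (0.30 log units; that floor lies within the scatter).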

Compound 4, half-maximal inhibitory concentration: > 10000 nM
Compound 4: only a limit was reported; the forecaster's own chance of this, stated with the estimate: 25%; at least 2.0-fold (0.30 log units) between middle value and limit.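

Compound 4 gives only a limit of the assay, as compound 3 does, so the step between these two cannot be read: the limit of > 10000 nM in this assay, at which 2 of the 4 values shown sit. Methyl in place of hydrogen on the saturated chain carbon bound to the amide-type nitrogen and the aromatic carbon gives an at least 1.6-fold higher number from compound 2 to compound 4 (0.22 log units; that floor lies within the scatter), so this floor does not yet show that the methyl matters. 1-(4-Fluorophenyl)ethyl in place of 4-chlorobenzyl gives an at least 10-fold higher number from compound 1 to compound 4 (1.00 log units; beyond the scatter), which shows that an aromatic ring in this group does not by itself hold the level of the chloro compound.

The compounds shown leave open whether a 1-(4-chlorophenyl)ethyl group on the amide-type nitrogen would stay close to compound 1 or end at a limit like compound 4. As far as these compounds go, the true size of the methyl's own effect also stays open.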